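This account rests on a few compounds, and the source may have more. Where it says the series, first, only, none or still open, it means among the compounds named here.

Compound 1 `COc1cc2c(Oc3ccc(NC(=O)N/N=C/c4ccc(C(F)(F)F)cc4)cc3F)ccnc2cc1OCCCN1CCCCC1` gives 660 nM in a functional assay on HT-29 cells (Homo sapiens) for cytotoxicity, read by MTT assay, with a stated time of 72 h; a higher number here means a weaker inhibitor, a lower number a stronger inhibitor.
Compound 2 `COc1cc2c(Oc3ccc(NC(=O)N/N=C/c4ccc(Cl)cc4Cl)cc3F)ccnc2cc1OCCCN1CCCCC1` gives 370 nM in this assay.
Compound 3 `COc1ccc(/C=N/NC(=O)Nc2ccc(Oc3ccnc4cc(OCCCN5CCCCC5)c(OC)cc34)c(F)c2)c(OC)c1` gives 1600 nM in this assay.

Compound 3 stands highest of the three numbers, and both gaps to it are beyond the scatter: a 2.4-fold higher number from compound 1 to compound 3 (0.38 log units; beyond the scatter) and a 4.3-fold higher number from compound 2 to compound 3 (0.64 log units; beyond the scatter). Compound 4 `COc1cc2c(Oc3ccc(NC(=O)N/N=C/c4ccncc4)cc3F)ccnc2cc1OCCCN1CCCCC1` differs from compound 3 by pyridin-4-yl in place of 2,4-dimethoxyphenyl on a carbon with a double bond to nitrogen. Going by the values given here, no measured step here involves pyridin-4-yl, so the data say nothing direct about this group. The two steps that bear on the change are the ones that swap the group on this same carbon: a 2.4-fold higher number from compound 1 to compound 3 (0.38 log units; beyond the scatter) and a 4.3-fold higher number from compound 2 to compound 3 (0.64 log units; beyond the scatter). Read in reverse, both show that replacing 2,4-dimethoxyphenyl by another aryl group moved the number down by modest amounts. From the compounds shown here alone, compound 4 is therefore expected to give a modestly lower number than compound 3, a 1.8-fold lower number from compound 3 to compound 4 (0.25 log units; within the scatter), though with wide uncertainty since pyridin-4-yl is untested. The estimate for compound 4 in this assay is 900 nM, with a range from 350 nM to 2500 nM.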

Compound 4, half-maximal inhibitory concentration: 940 nM
Estimate against measurement, compound 4: 1.0-fold (0.02 log units) below, within the range that was stated.
By their numbers in this assay, from the lowest: compounds 2, 1, 4 and 3 (each within the scatter of the next, the first and the last beyond it).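

In this assay, going by these compounds alone, pyridin-4-yl is the only group here whose ring holds a hetero atom, and on the carbon with a double bond to nitrogen it stays within the scatter of two carbon-only rings, with a 1.7-fold lower number from compound 3 to compound 4 (0.23 log units; within the scatter) and a 1.4-fold higher number from compound 1 to compound 4 (0.15 log units; within the scatter) as the two steps. Within the data shown here, only the 2,4-dichlorophenyl compound separates from it, with a 2.5-fold higher number from compound 2 to compound 4 (0.40 log units; beyond the scatter) as the one step beyond the scatter. Nothing available explains these differences.

The compounds shown leave open how pyridin-3-yl or pyridin-2-yl would compare with pyridin-4-yl on this carbon. They also leave open whether an aromatic ring is needed here at all, or whether a cyclohexyl ring or a short alkyl chain would give a similar number.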